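The source may hold more compounds than are shown below. What is called first, only, known or untested is meant among the compounds shown, and "the series" means these compounds.

Within the data shown here, compound 1 `Cn1ccc2c(Oc3ccc(NC(=O)c4cc5cccnc5n(-c5ccc(F)cc5)c4=O)cc3)ccnc21` is the only member of this small set with a number: in a functional assay on U-87MG ATCC cells for antiproliferative activity against U-87 MG (Homo sapiens), read by MTT assay, with a stated time of 72 h (on this read-out higher numbers stand for weaker inhibition and lower numbers for stronger inhibition), compound 1 gives 2120 nM. Compound 2 `Cn1ccc2c(Oc3ccc(NC(=O)c4cc5cccnc5n(-c5ccc(Br)cc5)c4=O)cc3)ccnc21` was run in this assay but for compound 2 the result reads "not determined" (no result reported), so compound 2 stands without a number of its own. Compound 3 `COc1ccc(-n2c(=O)c(C(=O)Nc3ccc(Oc4ccnc5c4ccn5C)cc3)cc3cccnc32)cc1` differs from compound 2 by methoxy in place of bromo on an aromatic carbon. Among the measured compounds shown here, with no measured step to lean on, the change is expected to move the read-out by no more than the usual scatter in either direction. On this basis compound 3 is estimated to give about 2500 nM in this assay, with a plausible range from 700 nM to 9000 nM.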

Compound 3, half-maximal inhibitory concentration: 5150 nM
Compound 3: the middle estimate sits 2.1-fold (0.31 log units) below what was measured; low and high end bracket the measured number.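

Among these compounds, compound 3 gives the first measured step at this position, on the aromatic carbon para to a large group: in this assay, methoxy in place of fluoro gives a 2.4-fold higher number from compound 1 to compound 3 (0.39 log units; beyond the scatter), so the read-out does respond to the group placed here. Of the two groups with numbers, methoxy reads as the weaker inhibitor. No measurement shown accounts for this shift. Where bromo would stand relative to fluoro and methoxy stays open, as compound 2 has no number. From the compounds shown here alone, how an amine, a carboxylic acid or a longer chain such as ethoxy would read here also stays open.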